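The source may report more compounds than this note shows. Statements on the series, on what has been measured and on what is new or still open speak of the compounds shown alone.

Measured compounds in an in vitro functional assay on HEK ts201 cells for antagonist activity at Neuronal acetylcholine receptor; alpha3/beta4 (Homo sapiens), read by fluorescence and calcium flux; on this read-out higher numbers stand for weaker inhibition and lower numbers for stronger inhibition:
- compound 1 `CC1CC(=O)N(c2ccccc2C(=O)OCC2CCCN(CCCCCc3ccccc3)C2)C1=O`: 4170 nM
- compound 2 `O=C(OCC1CCCN(C(=O)CCc2ccccc2)C1)c1ccccc1-c1ccccc1`: > 100000 nM; 331000 nM (2 entries)

Going by the values given here, compound 1 is the only compound of the two with a single number in this assay; compound 2 has several entries the several entries of compound 2 in this assay, > 100000 nM; 331000 nM (2 entries) and no single value, so no step between the two can be stated, and the two structures differ in more than one place. Compound 1 therefore stands as the sole reference point for this assay.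

Compound 3 `CC1CC(=O)N(c2ccccc2C(=O)OCC2CCCN(CCCCCOc3ccc(Cl)c(Cl)c3)C2)C1=O` has not been measured. It differs from compound 1 by 3,4-dichlorophenoxy in place of phenyl on a saturated chain carbon, five bonds along the chain from an amine nitrogen in a ring. Among the compounds with values here, no measured pair shares this change, so its size can only be expected, not read off. The expectation is a step that stays within the usual scatter, with at most a slight lean toward stronger inhibition. The step of a 1.4-fold lower number from compound 1 to compound 3 (0.14 log units; within the scatter) is what that estimate means. Compound 3 is expected to give about 3000 nM in this assay, with a range from 800 nM to 12000 nM.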

Compound 3, half-maximal inhibitory concentration: 9120 nM
Beside the measured number, compound 3's estimate is 3.0-fold (0.48 log units) below it; the range from low to high includes it.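

In this assay, going by these compounds alone, the change gives the first readable step at this place: a 2.2-fold higher number from compound 1 to compound 3 (0.34 log units; beyond the scatter), a modest move toward weaker inhibition. It shows that 3,4-dichlorophenoxy in place of phenyl, on a saturated chain carbon, five bonds along the chain from an amine nitrogen in a ring, shifts the read-out beyond the scatter, while compound 3 still gives a single value of 9120 nM on the core of compound 1. Nothing shown explains the direction or size of this step, as no measurement given here bears on it.

The change brings in the ether oxygen and both chlorines at once, so the compounds shown do not divide the step among them; an unsubstituted phenoxy and a 3,4-dichlorophenyl group at the same place are the comparisons that would separate these contributions. Steps involving compound 2 cannot be read, so it also stays open whether the change would act the same way on any other core.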